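Swapping the bicyclic amine on the shared core

A few compounds are considered here, and "the series" means these few. Any claim that something is new, unique, unknown or untested is made for them only; others in the source may bear on it.

Measured compounds:
compound 1 `Cn1c(=O)c(S(=O)(=O)c2ccc(F)cc2F)cc2cnc(Nc3ccc4cc[nH]c4c3)nc21` 5000 nM
compound 2 `Cn1ccc2cc(Nc3ncc4cc(S(=O)(=O)c5ccc(F)cc5F)c(=O)n(C)c4n3)ccc21` 750 nM
compound 3 `Cn1c(=O)c(S(=O)(=O)c2ccc(F)cc2F)cc2cnc(Nc3ccc4cccc(O)c4n3)nc21` 5000 nM

In a functional assay on K562 cells (Homo sapiens) for inhibition, read by trypan blue exclusion, with a stated time of 72 h (on this read-out higher numbers stand for weaker inhibition and lower numbers for stronger inhibition), compound 3 gives 5000 nM, level with compound 1 and together with it the highest number of the three; compound 2 sits clearly lower. Compound 4 `Cn1c(=O)c(S(=O)(=O)c2ccc(F)cc2F)cc2cnc(Nc3ccc4c(c3)CC(=O)N4)nc21` differs from compound 3 as follows: a group of 10 heavy atoms (8 carbon, 1 nitrogen, 1 oxygen; one five-membered non-aromatic ring with 1 hetero atom, one six-membered aromatic ring of carbon only) in place of a group of 11 heavy atoms (9 carbon, 1 nitrogen, 1 oxygen; one six-membered aromatic ring of carbon only, one six-membered aromatic ring with 1 hetero atom), on a nitrogen on an aromatic ring. Going by the values given here, two steps bear on this change: no change at the digits printed from compound 1 to compound 3 (within the scatter) and a 6.7-fold higher number from compound 2 to compound 3 (0.82 log units; beyond the scatter). Both concern the same position, but neither group that entered there matches the group entering in compound 4, so they only show that one swap left the number unchanged while another shifted it modestly. A step of a 1.3-fold lower number from compound 3 to compound 4 (0.10 log units; within the scatter) is expected, little beyond the scatter. Compound 4 is thus estimated at 4000 nM, within 1500 nM to 12000 nM.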

Compound 4, half-maximal inhibitory concentration: 15000 nM
Estimate against measurement, compound 4: 3.8-fold (0.57 log units) below, outside the stated range (above it).
By their numbers in this assay, from the lowest: compound 2; then compounds 1 and 3 (each within the scatter of the next); then compound 4.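

Compound 4 is the weakest of the four in this assay, so this position does not accept every bicyclic group: its group, with a five-membered non-aromatic ring, gives higher numbers than each group with two aromatic rings (a 3.0-fold higher number from compound 3 to compound 4 (0.48 log units; beyond the scatter); a 3.0-fold higher number from compound 1 to compound 4 (0.48 log units; beyond the scatter); a 20-fold higher number from compound 2 to compound 4 (1.30 log units; beyond the scatter)). Going by these compounds alone, the largest step is the one from the best compound so far, and no compound here goes against this pattern. Nothing measured here explains the loss. From the compounds shown here alone, it remains open how an amine or a carboxylic acid on the six-membered aromatic ring of the compound 4 group would change the number.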